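From ethoxycarbonyl to allyloxycarbonyl on compound 2

The compounds below may be only part of what the source reports. "The series", "measured", "known", "first", "only" and "open" are said of these compounds alone.

Values in a functional assay on A549 cells (Homo sapiens) for antiproliferative activity, read by MTT assay; on this read-out lower numbers stand for stronger inhibition and higher numbers for weaker inhibition:
- Compound 1 `O=C1NC(c2ccccc2)CN1S(=O)(=O)c1ccc2c(c1)CCCN2`: > 20000 nM (a limit)
- Compound 2 `CCOC(=O)N1CCCc2cc(S(=O)(=O)N3CC(c4ccccc4)NC3=O)ccc21`: 344 nM
- Compound 3 `CC(C)COC(=O)N1CCCc2cc(S(=O)(=O)N3CC(c4ccccc4)NC3=O)ccc21`: > 20000 nM (a limit)

Among the compounds with values here, compound 2, at 344 nM, holds the only true number here. The rest is the limit of > 20000 nM in this assay, at which 2 of the 3 values shown sit.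

Compound 4 `C=CCOC(=O)N1CCCc2cc(S(=O)(=O)N3CC(c4ccccc4)NC3=O)ccc21` has vinyl in place of methyl on a saturated chain carbon bound to an oxygen next to a carbonyl group, which turns ethoxycarbonyl into allyloxycarbonyl: vinyl in place of methyl on a saturated chain carbon bound to an oxygen next to a carbonyl group.

Within the data shown here, two steps bear on this. Adding ethoxycarbonyl gave an at least 58-fold lower number from compound 1 to compound 2 (1.76 log units; beyond the scatter). Exchanging that same methyl for isopropyl gave an at least 58-fold higher number from compound 2 to compound 3 (1.76 log units; beyond the scatter). A move in that same direction is therefore expected for compound 4, probably a shorter one.

The expected step is a 4.4-fold higher number from compound 2 to compound 4 (0.64 log units; beyond the scatter). For compound 4 the estimated value is 1500 nM, with an expected range of 250 nM to 20000 nM.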

Compound 4, half-maximal inhibitory concentration: 4310 nM
Estimate against measurement, compound 4: 2.9-fold (0.46 log units) below; low and high end bracket the measured number.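

In this assay, replacing methyl with vinyl at this place costs much of the activity: a 13-fold higher number from compound 2 to compound 4 (1.10 log units; beyond the scatter). Within the data shown here, compound 4 shows a middle ground that the earlier compounds did not. Allyloxycarbonyl still gives a true number, with an at least 4.6-fold lower number from compound 3 to compound 4 (0.66 log units; beyond the scatter) and an at least 4.6-fold lower number from compound 1 to compound 4 (0.66 log units; beyond the scatter). Those two steps start from limits, not true numbers: the limit of > 20000 nM in this assay, at which 2 of the 4 values shown sit.

Going by these compounds, whether the loss follows the double bond or the extra carbon stays open, and a saturated propyl at this place would separate the two. On these data alone, how a shorter methoxycarbonyl compares with ethoxycarbonyl also stays open.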